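The source may hold more compounds than are shown below. What is called first, only, known or untested is meant among the compounds shown, and "the series" means these compounds.

Measured in an ADME assay on HEK293 cells (Homo sapiens) for cytotoxicity, read by CCK-8 assay and cell counting, with a stated time of 2 days; on this read-out higher numbers stand for weaker inhibition and lower numbers for stronger inhibition:

- compound 1 `Oc1ccc(-c2cc(-c3cccc(Cl)c3)nc(-c3cccs3)c2)cc1`: 2720 nM
- compound 2 `Oc1ccc(-c2cc(-c3ccc(Cl)cc3)nc(-c3ccsc3)c2)cc1`: 4860 nM
- compound 3 `Oc1cccc(-c2cc(-c3ccsc3)nc(-c3cccc(Cl)c3)c2)c1`: 3180 nM

In this assay, compound 3 gives 3180 nM, a value within the usual scatter of both other compounds, so the three cannot be told apart on these numbers.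

Compound 4 `Oc1ccc(-c2cc(-c3ccsc3)nc(-c3cccc(Cl)c3)c2)cc1` has the same atoms as compound 3, joined differently: 4-hydroxyphenyl stands in place of 3-hydroxyphenyl on an aromatic carbon, opposite the ring nitrogen (4-hydroxyphenyl in place of 3-hydroxyphenyl on an aromatic carbon). Among the measured compounds shown here, no measured pair isolates this change, so the expectation rests on the values at hand. Two compounds that already carry 4-hydroxyphenyl offer the closest guide: compound 1 gives 2720 nM and compound 2 gives 4860 nM. Neither value is separated from that of compound 3 by more than the scatter, although each of these compounds also differs from it elsewhere. The expected step of a 1.1-fold higher number from compound 3 to compound 4 (0.03 log units; within the scatter) therefore stays within the scatter, with no clear direction. For compound 4 the estimated value is 3400 nM, with an expected range from 1800 nM to 6400 nM.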

Compound 4, half-maximal inhibitory concentration: 2670 nM
The estimate for compound 4 lay 1.3-fold (0.10 log units) above the measured number; low and high end bracket the measured number.
By their numbers in this assay, from the lowest: compounds 4, 1, 3 and 2 (each within the scatter of the next).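

Among the compounds shown here, compound 4 gives the first one-place comparisons in this assay: on the aromatic carbon opposite the ring nitrogen, 4-hydroxyphenyl in place of 3-hydroxyphenyl gives a step within the scatter (a 1.2-fold lower number from compound 3 to compound 4 (0.08 log units; within the scatter)). The two other swaps of attachment point also stay within the scatter, with 3-chlorophenyl in place of 4-chlorophenyl (a 1.8-fold lower number from compound 2 to compound 4 (0.26 log units; within the scatter)) and thiophen-3-yl in place of thiophen-2-yl (a 1.0-fold lower number from compound 1 to compound 4 (0.01 log units; within the scatter)), so none of these three changes separates its pair of compounds. No supporting measurement bears on these results.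

All four compounds carry a hydroxyphenyl, a chlorophenyl and a thiophene group, differing only in how these are attached. As far as these compounds go, whether an amine or a carboxylic acid in place of the hydroxyl would shift the number beyond the scatter remains open.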